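This account rests on a few compounds, and the source may have more. Where it says the series, first, only, none or still open, it means among the compounds named here.

In an assay on Sf9 cells for inhibition of tyrosine-protein kinase receptor UFO (Homo sapiens), read by luminescence and ADP-Glo (a lower number here means a stronger inhibitor, a higher number a weaker inhibitor), compound 1 `Cc1ccc(Nc2ncc(C(F)(F)F)c(N3Cc4cccc(N(C)S(C)(=O)=O)c4C3)n2)cc1C` gives > 20000 nM, which is a limit of the assay rather than a number. Compound 2 `COc1cc(Nc2ncc(C(F)(F)F)c(N3Cc4cccc(N(C)S(C)(=O)=O)c4C3)n2)c(OC)cc1Cl` gives > 20000 nM, again a limit. Compound 3 `CN(c1cccc2c1CN(c1nc(Nc3ccc(C(F)(F)F)cc3)ncc1C(F)(F)F)C2)S(C)(=O)=O` gives > 20000 nM, also a limit. All three values sit at one point, (the limit of > 20000 nM in this assay, at which 3 of the 3 values shown sit), so the three steps among them, a step that the two limits leave unreadable from compound 1 to compound 2, a step that the two limits leave unreadable from compound 1 to compound 3 and a step that the two limits leave unreadable from compound 2 to compound 3, cannot be read: the two limits hide whatever difference exists within each pair. What the three measured compounds do show is that swapping one aryl group on that ring nitrogen for another, in each of these cases, never brought a value below the limit.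

Compound 4 `Cc1cc(Cl)ccc1Nc1ncc(C(F)(F)F)c(N2Cc3cccc(N(C)S(C)(=O)=O)c3C2)n1` has not yet been measured. It differs from compound 1 in one place: 4-chloro-2-methylphenyl in place of 3,4-dimethylphenyl on a nitrogen on an aromatic ring. Within the data shown here, no measured step gives a readable size, so there is nothing to scale this change against, only the observation that the related swaps each left the value at the limit. The step that the limit leaves unreadable from compound 1 to compound 4 is therefore expected to be small or unreadable, with the new value most likely reported as a limit once more. Compound 4 is estimated at 30000 nM, within a range from 8000 nM to 100000 nM.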

Compound 4, half-maximal inhibitory concentration: > 20000 nM
Compound 4 was reported as a limit; the forecaster's own chance of this, stated with the estimate: 85%; the middle value lies beyond the limit too.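

Compound 4 is also a limit of the assay, so no step from compound 1, compound 2 or compound 3 to compound 4 can be read: the limit of > 20000 nM in this assay, at which 4 of the 4 values shown sit.

What the compounds shown leave open is how strongly any of them inhibits in this assay, and whether any change of this aryl group would matter.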